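Ether-bearing chain in place of trifluoropropyl on the shared core

This account rests on a few compounds, and the source may have more. Where it says the series, first, only, none or still open, it means among the compounds named here.

The compounds share the core of compound 1 `Nc1ccc2cccc(OCCC(F)(F)F)c2n1` and differ in the chain on the aromatic oxygen. In an assay on cells with melanin-concentrating hormone receptor 1 (Homo sapiens) as the target, read by radioligand binding (a higher number here means a weaker inhibitor, a lower number a stronger inhibitor), compound 1 gives 722 nM, the lower of the two numbers shown, while compound 2 `Nc1ccc2cccc(OCCC3CCCCC3)c2n1` gives 808 nM; the step of a 1.1-fold higher number from compound 1 to compound 2 (0.05 log units; within the scatter) is within the scatter, so the two are not distinguished. Compound 3 `CC(CC(C)(C)C)Oc1cccc2cccnc12` gives > 2000 nM, which is a limit of this assay rather than a number (the limit of > 2000 nM in this assay, at which 1 of the 3 values shown sits).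

Compound 4 `CCOCC(C)Oc1cccc2ccc(N)nc12` arises from compound 1 by a group of 6 heavy atoms (5 carbon, 1 oxygen; no ring) in place of a group of 6 heavy atoms (3 carbon, 3 fluorine; no ring), on an oxygen on an aromatic ring. For the measured compounds named here, the only measured step on this chain, a 1.1-fold higher number from compound 1 to compound 2 (0.05 log units; within the scatter), lies within the scatter, so no step beyond the scatter is expected in this assay. Compound 4 is therefore estimated at 900 nM, with a range from 300 nM to 2700 nM. The expected step is a 1.2-fold higher number from compound 1 to compound 4 (0.10 log units; within the scatter).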

Compound 4, half-maximal inhibitory concentration: 1070 nM
Compound 4: middle estimate off by 1.2-fold (0.08 log units), on the low side; low and high end bracket the measured number.
By their numbers in this assay, from the lowest: compounds 1, 2 and 4 (each within the scatter of the next). At a limit, above all of these: compound 3.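

Putting a group with one hydrogen-bond acceptor in place of 3,3,3-trifluoropropyl, on an oxygen on an aromatic ring, gives a 1.5-fold higher number from compound 1 to compound 4 (0.17 log units; within the scatter), so this assay does not tell these two compounds apart. Fluorine is therefore not required at this position for a number in this range. No measured property among the data shown bears on this step.

On these data alone, whether an amine or a carboxylic acid on this chain would move the number beyond the scatter remains open. So does the effect of a longer ether chain.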